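A few compounds are considered here, and "the series" means these few. Any claim that something is new, unique, unknown or untested is made for them only; others in the source may bear on it.

In a functional assay on NCI-H23 cells (Homo sapiens) for cytotoxicity, read by sulforhodamine B assay, with a stated time of 72 h (a higher number here means a weaker inhibitor of growth, a lower number a stronger inhibitor of growth), compound 1, with the structure `O=C(Nc1cc(C(F)(F)F)cc(C(F)(F)F)c1)C1CCc2ccccc2N1C(=O)c1ccccc1Cl`, gives 2080 nM. Compound 2, `CC(=O)N1c2ccccc2CCC1C(=O)Nc1ccccc1O`, gives 65700 nM in this assay. Compound 3, `CCCC(=O)N1c2ccccc2CCC1C(=O)Nc1ccccc1C(F)(F)F`, stands in this assay only as a limit, > 70000 nM, and no number is known for it. The limit in question is the limit of > 70000 nM in this assay, at which 1 of the 3 values shown sits. Within the data shown here, of the three measured compounds, compound 1 alone carries an aromatic ring on the carbonyl attached to the ring nitrogen of the shared core, and it is also the only one whose value sits well inside the measured range; compound 2 and compound 3, each with a short chain there, show the weak end of what was seen.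

Compound 4, `O=C(Nc1ccccc1C(F)(F)F)C1CCc2ccccc2N1C(=O)c1cccc(Cl)c1`, differs from compound 3 in one place: 3-chlorophenyl in place of propyl on a carbonyl carbon. The other amide of compound 4 stays as in compound 3. Among the measured compounds shown here, no pair of measured compounds differs in this place alone, and compound 1 differs from compound 3 in two places, so what those two show cannot be split into parts.

Compound 4 is nonetheless expected to gain, with the step of an at least 4.6-fold lower number from compound 3 to compound 4 (0.66 log units; beyond the scatter) from compound 3 to compound 4 estimated as beyond the scatter, though the starting point is only a limit. Compound 4 is estimated at 15000 nM, expected between 3000 nM and 70000 nM.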

Compound 4, concentration for 50% growth inhibition: 292 nM
Compound 4: the middle estimate sits 51-fold (1.71 log units) above what was measured, and the stated range ends above it.
By their numbers in this assay, from the lowest: compound 4; then compound 1; then compound 2. At a limit, above all of these: compound 3.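

Among these compounds, this is the first pair of measured compounds that differ in one place only, and it shows that the group on a carbonyl carbon bound to an amide-type nitrogen in a ring has a strong bearing on the result in this assay. Putting 3-chlorophenyl in place of propyl there, with the other amide left unchanged, gives an at least 230-fold lower number from compound 3 to compound 4 (2.37 log units; beyond the scatter), a large step that lies beyond the scatter. Compound 3 stands only at a limit, so the true size of this step stays unknown and the printed figure marks only its smallest possible size: the limit of > 70000 nM in this assay, at which 1 of the 4 values shown sits.

The compounds shown leave open whether the gain belongs to the aromatic ring as such or to its chlorine, a question that a plain phenyl on the same carbonyl carbon would separate. They also leave open how a longer chain, such as hexyl, or a ring bearing an amine or a carboxylic acid would compare in that place with propyl and 3-chlorophenyl.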